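Cytotoxicity notes: the step from compound 3 to compound 4

The source may hold more compounds than are shown below. What is called first, only, known or untested is meant among the compounds shown, and "the series" means these compounds.

In an ADME assay on HEL cells (Homo sapiens) for cytotoxicity, with a stated time of 3 days (on this read-out lower numbers stand for higher toxicity in this test and higher numbers for lower toxicity in this test), compound 1 `Cc1cc(-c2ccsc2)c2ncc(CSCc3ccccc3)n2c1` gives 100 ug/mL.
In this assay compound 2 `Cc1cc(-c2ccco2)c2ncc(CSCCc3ccccc3)n2c1` gives 100 ug/mL.
In this assay compound 3 `Cc1cc(N2CCCC2)c2ncc(CSCCc3ccccc3)n2c1` reaches only the limit > 100 ug/mL, a limit of the assay and not a number.

Compound 3 thus stands at a limit in this assay, the top of the values seen here, with no number of its own; one of the three values sits there (the limit of > 100 ug/mL in this assay, at which 1 of the 3 values shown sits). Going by the values given here, the single measured step, a number no lower from compound 2 to compound 3 (the limit leaves the size open), has no readable size for the same reason. Compound 4 `Cc1cc(N2CCCC2)c2ncc(CSCc3ccccc3)n2c1` differs from compound 3 by phenyl in place of benzyl on a saturated chain carbon bound to a sulfur. Among the compounds with values here, no measured pair isolates this change; compounds 1 and 2 differ in two places and show the same number. In this assay the expectation for compound 4 is therefore no step beyond the scatter, a number no higher from compound 3 to compound 4 (the limit leaves the size open). Compound 4 is estimated at 100 ug/mL, within 50 ug/mL to 200 ug/mL, with a good chance that only a limit is reported.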

Compound 4, minimum cytotoxic concentration: >= 20 ug/mL
Compound 4: a limit, no number (the forecaster's own chance of this, stated with the estimate: 55%); the middle value lies beyond the limit too.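

In this assay compound 4 gives only a limit, not a number, so neither step, from compound 3 or from compound 1 to compound 4, can be read. The compounds shown leave open whether phenyl in place of benzyl shifts the read-out at all.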